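The source may report more compounds than this note shows. Statements on the series, on what has been measured and on what is new or still open speak of the compounds shown alone.

Of the compounds shown here, two have numbers so far. Compound 1 `CS(=O)(=O)CCCOc1ccc2c(c1)OC(COc1ccc(CCC(=O)O)c(F)c1)CC2` in a functional assay on HEK293 cells for agonist activity at Free fatty acid receptor 1 (Homo sapiens), read by fluorescence and calcium flux, with a stated time of 10 min (a lower number here means that less compound is needed, a higher number that more compound is needed for the effect), gives 36300 nM. Compound 2 `CCOC(CC(=O)O)c1ccc(OCC2COc3ccc(Cl)cc3O2)cc1` in this assay gives 640 nM, the lower of the two numbers; the gap from compound 2 to compound 1 is well beyond the scatter, so compound 2 stands as the more potent of the pair on the values shown.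

Compound 3 `O=C(O)CC(c1ccc(F)cc1)c1ccc(OCC2COc3ccc(Cl)cc3O2)cc1` shares the core of compound 2 and differs from it at one place only: 4-fluorophenyl in place of ethoxy on a saturated chain carbon bound to an aromatic carbon and a saturated chain carbon. Nothing measured within the series covers this change, so the expected step rests on the structures alone. The carboxylic acid and the core are unchanged, and the exchanged group sits on the chain carbon that carries the acid side chain.

A small step is expected here, most likely toward a lower number; the step from compound 2 to compound 3 is estimated at a 2.1-fold lower number from compound 2 to compound 3 (0.33 log units; beyond the scatter), which need not clear the scatter. For compound 3 the expected value in this assay is 300 nM, with a range from 80 nM to 1500 nM.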

Compound 3, half-maximal effective concentration: 4310 nM
Compound 3: middle estimate off by 14-fold (1.16 log units), on the low side; measured number above the stated range.
By their numbers in this assay, from the lowest: compound 2; then compound 3; then compound 1.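

At the saturated chain carbon bound to an aromatic carbon and a saturated chain carbon, the series now has its first measured exchange: in this assay, 4-fluorophenyl in place of ethoxy brings a 6.7-fold higher number from compound 2 to compound 3 (0.83 log units; beyond the scatter) and so shows that the number responds to what this carbon carries. The change replaces a group of 3 heavy atoms holding one hydrogen-bond acceptor with a group of 7 heavy atoms holding a six-membered aromatic ring of carbon only and no hydrogen-bond acceptor, and in this single pair the ethoxy compound keeps the lower number. No measurement at hand bears on why the number moves in this direction.

The step cannot yet be divided between the departure of the ethoxy oxygen and the arrival of the fluorinated ring, since both happen together in this one pair. A methoxy or propoxy group, an unsubstituted phenyl, or a plain hydrogen at the same chain carbon would show how the number depends on chain length, on the fluorine and on the presence of any group there at all.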